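This account rests on a few compounds, and the source may have more. Where it says the series, first, only, none or still open, it means among the compounds named here.

Compound 1 `Nc1scc(CN2CCN(c3cccc(Cl)c3Cl)CC2)c1C(=O)c1ccc(Cl)cc1` carries a 2,3-dichlorophenyl group on the amine nitrogen of its piperazine-like ring, and in a functional assay on CHO cells with adenosine receptor A1 (Homo sapiens) as the target, read by cAMP accumulation and immunoassay, with a stated time of 6 min, tested at 1 uM (on this read-out lower numbers stand for a stronger effect and higher numbers for a weaker effect at the one concentration tested), compound 1 gives -57%. Compound 2 `Nc1scc(CN2CCN(c3cccnc3)CC2)c1C(=O)c1ccc(Cl)cc1` differs from it in one place, and in this assay compound 2 gives -2.7%. For the measured compounds named here, the change from one to the other is a number 54.3 percentage points higher from compound 1 to compound 2 (beyond the scatter), so compound 2 holds the highest of the two numbers measured so far, with compound 1 as its only neighbour, far beyond the scatter.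

Compound 3 `Nc1scc(CN2CCN(c3cccc(F)c3F)CC2)c1C(=O)c1ccc(Cl)cc1` has not yet been measured. It is obtained from compound 2 by the change (2,3-difluorophenyl in place of pyridin-3-yl on an amine nitrogen in a ring). Going by the values given here, the only measured step that bears on this move is the one from compound 1 to compound 2, which ran in the opposite structural direction, a dihalophenyl giving way to pyridin-3-yl, and was large. Compound 3 brings a dihalophenyl back, though with fluorine rather than chlorine, so a sizeable drop is expected from compound 2 to compound 3, namely a number 32.3 percentage points lower from compound 2 to compound 3 (beyond the scatter) in this assay. Compound 3 is therefore estimated at -35%, within a range from -65% to -5%.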

Compound 3, a percentage reported as activity, at one concentration (the size of the read-out at that concentration, not a potency): -66%
The estimate for compound 3 lay 31 percentage points above the measured number, and the stated range ends above it.
By their numbers in this assay, from the lowest: compounds 3 and 1 (each within the scatter of the next); then compound 2.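

In this assay, the replacement of pyridin-3-yl by 2,3-difluorophenyl on the amine nitrogen in the ring gives a number 63.3 percentage points lower from compound 2 to compound 3 (beyond the scatter), so the large difference between a dihalophenyl group and pyridin-3-yl at this position now holds for a second pair of halogens. The exchange of chlorine for fluorine gives a number 9 percentage points lower from compound 1 to compound 3 (within the scatter), which means that the read-out at this one concentration does not separate 2,3-difluorophenyl from 2,3-dichlorophenyl; among these three compounds, the large difference lies between pyridin-3-yl and the two dihalophenyl groups, and neither dihalophenyl group goes against it. No measurement available here gives a reason for this difference.

Pyridin-3-yl and the dihalophenyl groups differ both in the ring nitrogen and in the two halogens, so these compounds cannot show which of the two matters, and a plain phenyl group would be needed to separate them. From the compounds shown here alone, it also remains open whether the halogens can give way to methyl or methoxy groups at this position without a step as large as the one seen with pyridin-3-yl.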